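Halogen and side-chain steps in a small series

This account rests on a few compounds, and the source may have more. Where it says the series, first, only, none or still open, it means among the compounds named here.

Values in an ADME assay on L6 cells (Rattus norvegicus) for inhibition, read by resazurin assay, with a stated time of 72 h (on this read-out higher numbers stand for weaker inhibition and lower numbers for stronger inhibition), so far:
- compound 1 `CS(=O)(=O)C[C@H]1O[C@@H](n2cnc3c(N)nc(F)nc32)[C@H](O)[C@@H]1O` gives 5000 nM
- compound 2 `CS(=O)(=O)C[C@H]1O[C@@H](n2cnc3c(N)nc(Cl)nc32)[C@H](O)[C@@H]1O` gives 156000 nM

Compound 2 holds the higher of the two numbers (156000 nM) and is therefore the weaker inhibitor, beyond the scatter from compound 1. The next entry, compound 3 `CC(=O)NC[C@H]1O[C@@H](n2cnc3c(N)nc(Cl)nc32)[C@H](O)[C@@H]1O`, keeps the chloro and carries acetamido in place of methylsulfonyl on a saturated chain carbon bound to a saturated ring carbon. Within the data shown here, the only measured step (a 31-fold higher number from compound 1 to compound 2 (1.49 log units; beyond the scatter)) is large, but it is chloro in place of fluoro on an aromatic carbon, a different place in the molecule. Among the measured compounds shown here, no measured step covers a change at the chain carbon, so the data give neither its size nor its direction in this assay directly. With compound 2 at the top of the measured range (156000 nM), a modest move to a lower number is expected, held with little confidence. The expected change is thus a moderate one (a 1.7-fold lower number from compound 2 to compound 3 (0.24 log units; within the scatter)). The estimated value for compound 3 is 90000 nM (expected range 20000 nM to 250000 nM).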

Compound 3, half-maximal inhibitory concentration: 189000 nM
Beside the measured number, compound 3's estimate is 2.1-fold (0.32 log units) below it, within the range that was stated.
By their numbers in this assay, from the lowest: compound 1; then compounds 2 and 3 (each within the scatter of the next).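

In this assay, the first step read at the saturated chain carbon bound to a saturated ring carbon, acetamido in place of methylsulfonyl with the chloro held fixed, gives a 1.2-fold higher number from compound 2 to compound 3 (0.08 log units; within the scatter) and so does not separate the two compounds. This exchange takes out a group with 0 hydrogen-bond donors and 2 double bonds outside aromatic rings and puts in one with 1 hydrogen-bond donor and 1 such double bond, yet the two numbers stay within the scatter of each other, whereas the halogen step, a 31-fold higher number from compound 1 to compound 2 (1.49 log units; beyond the scatter) in the same read-out, lies beyond it. No measured property is available that bears on this result.

Still open, on these data alone, is whether an amine or a carboxylic acid on this chain carbon would give a step beyond the scatter, in either direction. Also open is whether acetamido and methylsulfonyl would remain within the scatter of each other with fluoro rather than chloro on the aromatic carbon, as the one comparison shown at the chain carbon carries chloro.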